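Isobutyl for Isopropyl: Expected Tolerance of Compound 4

The source may hold more compounds than are shown below. What is called first, only, known or untested is meant among the compounds shown, and "the series" means these compounds.

Of the compounds shown here, three have been tested in an ADME assay on H1-HeLa cells (Homo sapiens) for cytotoxicity, read by MTT assay, with a stated time of 3 days; a lower number here means that less compound is tolerated, a higher number that more compound is tolerated. Compound 1, `CNC(=O)c1cc(Oc2ccc(-c3noc(C(C)C)n3)cc2)ccn1`, gives 16100 nM. Compound 2, `CNC(=O)c1cc(Oc2ccc(-c3noc(CC(C)C)n3)cc2)ccn1`, gives 23400 nM. Compound 3, `CNC(=O)c1cc(Oc2cccc(-c3noc(C(C)C)n3)c2)ccn1`, gives 54200 nM, the highest of the three numbers, meaning it is the best tolerated by the cells of those measured.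

Compound 1 and compound 2 differ in a single place: isobutyl in place of isopropyl on an aromatic carbon. This change gives a 1.5-fold higher number from compound 1 to compound 2 (0.16 log units; within the scatter), so the cells tolerate the two compounds to much the same degree. Compound 3 is built from the same atoms as compound 1 but joined differently; the difference between the two cores is not broken down here.

Compound 4, `CNC(=O)c1cc(Oc2cccc(-c3noc(CC(C)C)n3)c2)ccn1`, has not yet been measured. It relates to compound 3 exactly as compound 2 relates to compound 1: isobutyl in place of isopropyl on an aromatic carbon. The surroundings of the change are the same in both pairs, so this is the same change made on the core of compound 3 instead of the core of compound 1.

Given that the one measured example of this change gave a 1.5-fold higher number from compound 1 to compound 2 (0.16 log units; within the scatter), the step from compound 3 to compound 4 is expected to be similar, a 1.3-fold higher number from compound 3 to compound 4 (0.11 log units; within the scatter). On that basis compound 4 is estimated to give 70000 nM in this assay. For compound 4 the expected range runs from 35000 nM to 140000 nM, resting on a single prior example and so remaining uncertain.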

Compound 4, half-maximal cytotoxic concentration: 19100 nM
Compound 4: middle estimate off by 3.7-fold (0.56 log units), on the high side; measured number below the stated range.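

On the core of compound 3, isobutyl in place of isopropyl gives a 2.8-fold lower number from compound 3 to compound 4 (0.45 log units; beyond the scatter) in this assay, so here the larger chain goes with less compound being tolerated by the cells. This does not match the result on the core of compound 1, and it shows that in this series the step measured on one core cannot simply be carried over to the other. For the compounds shown here, it does not show why the two cores respond differently, and with only two pairs it cannot say which result, if either, would be typical of further cores. The comparison of the two steps makes the mismatch plain: the same change on two cores in this assay, a 1.5-fold higher number (0.16 log units; within the scatter) from compound 1 to compound 2 and a 2.8-fold lower number (0.45 log units; beyond the scatter) from compound 3 to compound 4, 4.1-fold (0.62 log units) apart, beyond the scatter of two such steps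

The compounds shown leave open what other groups would do at this same place on the five-membered ring, such as a smaller methyl, a longer chain like n-butyl, or a chain ending in an amine or a carboxylic acid. They also leave open whether such groups would give steps that differ between the core of compound 1 and the core of compound 3, as isobutyl does here.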